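From 4-Methylbenzyl to Acetyl on the Shared Core

The source may report more compounds than this note shows. Statements on the series, on what has been measured and on what is new or still open speak of the compounds shown alone.

Measured in an ADME assay on L6 cells (Rattus norvegicus) for cytotoxicity, read by resazurin assay, with a stated time of 70 h; on this read-out higher numbers stand for weaker inhibition and lower numbers for stronger inhibition:
- compound 1 `CC(=O)Oc1ccc2c(c1)C(C)=CC(C)(C)N2Cc1ccc(C)cc1`: 21000 nM
- compound 2 `CC(=O)Oc1ccc2c(c1)C(C)=CC(C)(C)N2Cc1ccc(Cl)c(Cl)c1`: 28000 nM
- compound 3 `CC(=O)Oc1ccc2c(c1)C(C)=CC(C)(C)N2Cc1ccc(C(F)(F)F)cc1`: 14000 nM

Compound 1 stands with both other measured compounds within the scatter: the steps are a 1.3-fold higher number from compound 1 to compound 2 (0.12 log units; within the scatter) and a 1.5-fold lower number from compound 1 to compound 3 (0.18 log units; within the scatter). The next compound to be tested, compound 4 `CC(=O)Oc1ccc2c(c1)C(C)=CC(C)(C)N2C(C)=O`, carries a much larger change from compound 1: acetyl in place of 4-methylbenzyl on a nitrogen on an aromatic ring in a ring. In words, this is acetyl in place of 4-methylbenzyl on a nitrogen on an aromatic ring in a ring.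

The two measured steps bear on this change only indirectly. One puts 3,4-dichlorophenyl in place of 4-methylphenyl, and the other puts trifluoromethyl in place of methyl on an aromatic carbon. Among the compounds with values here, neither replaces the whole 4-methylbenzyl, so the data offer no direct precedent. Their small size says little about a change of this scale, and a modest move towards a higher number, meaning weaker inhibition, is only a tentative expectation. The expected step is a 2.1-fold higher number from compound 1 to compound 4 (0.33 log units; beyond the scatter). The estimated value for compound 4 is 45000 nM, with an expected range from 15000 nM to 130000 nM.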

Compound 4, half-maximal inhibitory concentration: 160000 nM
Compound 4: the middle estimate sits 3.6-fold (0.55 log units) below what was measured; measured number outside the range, above it.
By their numbers in this assay, from the lowest: compounds 3, 1 and 2 (each within the scatter of the next); then compound 4.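

In this assay, within the data shown here, the group on this nitrogen matters in a way the earlier changes on the benzyl ring did not show: acetyl in place of 4-methylbenzyl gives the only step here beyond the scatter (a 7.6-fold higher number from compound 1 to compound 4 (0.88 log units; beyond the scatter)). The position therefore responds, towards weaker inhibition, when the 4-methylbenzyl with its six-membered aromatic ring of carbon only gives way to acetyl, which has no ring and carries one hydrogen-bond acceptor. Nothing available explains this shift or divides it among the parts of the change.

Going by these compounds, whether the step follows the loss of the aromatic ring or the arrival of the carbonyl on the nitrogen stays open. A benzoyl group or a plain ethyl group on this nitrogen would separate those two parts of the change.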